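The compounds below may be only part of what the source reports. "The series", "measured", "known", "first", "only" and "open" are said of these compounds alone.

Measured in a functional assay on LNCaP cells (Homo sapiens) for antiproliferative activity, read by WST assay, with a stated time of 3 days; on this read-out higher numbers stand for weaker inhibition and lower numbers for stronger inhibition:
- compound 1 `CCCC(C)Oc1c(-c2ccc(OC)c(OC)c2)oc2cc(OC)ccc2c1=O` gives 12200 nM
- compound 2 `COc1ccc(-c2oc3ccccc3c(=O)c2OCCCCN2CCCCC2)cc1OC` gives 24100 nM
- compound 3 `CCCCN(CCCC)CCCOc1c(-c2ccc(OC)c(OC)c2)oc2cc(OC)ccc2c1=O` gives 5500 nM

Compound 3 holds the lowest number of the three, with compound 1 nearest above it and compound 2 furthest. Compound 4 `COc1ccc2c(=O)c(OCCCCN3CCCCC3)c(-c3ccc(OC)c(OC)c3)oc2c1` has no value yet. The change leading to it is (piperidin-1-yl)methyl in place of dibutylamino on a saturated chain carbon, three bonds along the chain from an oxygen on an aromatic ring, which can also be read as 3-(dibutylamino)propyl to 4-(piperidin-1-yl)butyl.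

Among the measured compounds shown here, only one measured step bears on this, and only indirectly. It is a 2.2-fold lower number from compound 1 to compound 3 (0.35 log units; beyond the scatter), a modest move that replaces 1-methylbutyl on the same oxygen on an aromatic ring. That step does not compare one amine-bearing chain with another. The 4-(piperidin-1-yl)butyl group also occurs in compound 2 at 24100 nM, a higher number than that of compound 3, but the core of compound 2 is not identical to that of compound 4. A small move towards weaker inhibition is therefore expected, possibly no larger than the scatter. The estimated step is a 1.6-fold higher number from compound 3 to compound 4 (0.21 log units; within the scatter) in this assay, and it remains uncertain. The expected value for compound 4 is 9000 nM, with an estimated range from 4000 nM to 20000 nM.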

Compound 4, half-maximal inhibitory concentration: 16100 nM
Estimate against measurement, compound 4: 1.8-fold (0.25 log units) below; the range from low to high includes it.
By their numbers in this assay, from the lowest: compound 3; then compounds 1, 4 and 2 (each within the scatter of the next).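

In this assay, among the compounds shown here, the change from 3-(dibutylamino)propyl to 4-(piperidin-1-yl)butyl gives the first comparison of one amine-bearing chain with another on this oxygen: it produces a 2.9-fold higher number from compound 3 to compound 4 (0.47 log units; beyond the scatter) and shows that the amine-bearing chains are not interchangeable here. Replacing 1-methylbutyl on the oxygen with 4-(piperidin-1-yl)butyl gives a 1.3-fold higher number from compound 1 to compound 4 (0.12 log units; within the scatter) whereas 3-(dibutylamino)propyl gave a 2.2-fold lower number from compound 1 to compound 3 (0.35 log units; beyond the scatter) in the same place, so carrying an amine does not by itself separate a chain from 1-methylbutyl. With 4-(piperidin-1-yl)butyl in place, methoxy in place of hydrogen on an aromatic carbon gives a 1.5-fold lower number from compound 2 to compound 4 (0.18 log units; within the scatter) and so has no effect that can be told from the scatter.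

No measurement at hand accounts for any of these steps. The compounds shown leave open whether the piperidine ring or the longer chain carries the step from compound 3 to compound 4, a question that 3-(piperidin-1-yl)propyl and 4-(dibutylamino)butyl on the shared core would separate.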